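Notes on replacing chloro with (4-chlorophenyl)carbamoyl

The compounds below may be only part of what the source reports. "The series", "measured", "known", "first", "only" and "open" are said of these compounds alone.

Measured in a functional assay on NCI-H1975 cells (Homo sapiens) for cytotoxicity, read by MTT assay, with a stated time of 72 h; a lower number here means a stronger inhibitor, a higher number a weaker inhibitor:
- compound 1 `C#Cc1cccc(Nc2nc3cnc(Nc4ccc(N5CCN(C)CC5)cc4)nc3n2C2CCCC2)c1`: 650 nM
- compound 2 `CN1CCN(c2ccc(Nc3ncc4nc(Nc5cccc(Cl)c5)n(C5CCCC5)c4n3)cc2)CC1`: 390 nM

Compound 2 stands level with compound 1, within the scatter. Compound 3 `CN1CCN(c2ccc(Nc3ncc4nc(Nc5cccc(C(=O)Nc6ccc(Cl)cc6)c5)n(C5CCCC5)c4n3)cc2)CC1` carries (4-chlorophenyl)carbamoyl in place of chloro on an aromatic carbon. Going by the values given here, the only measured step, a 1.7-fold lower number from compound 1 to compound 2 (0.22 log units; within the scatter), exchanged groups far smaller than the one entering here, so it sets no direction. No clear move is therefore expected in this assay, though the uncertainty is wide. The expected step is a 1.3-fold higher number from compound 2 to compound 3 (0.11 log units; within the scatter). Compound 3 is estimated at 500 nM, with an expected range of 120 nM to 2000 nM.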

Compound 3, half-maximal inhibitory concentration: 4010 nM
Compound 3: middle estimate off by 8.0-fold (0.90 log units), on the low side; the measured number lies above the stated range.
By their numbers in this assay, from the lowest: compounds 2 and 1 (each within the scatter of the next); then compound 3.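

In this assay this place on the aromatic ring responds strongly to the group it carries: (4-chlorophenyl)carbamoyl in place of chloro gives a 10-fold higher number from compound 2 to compound 3 (1.01 log units; beyond the scatter) and in place of ethynyl gives a 6.2-fold higher number from compound 1 to compound 3 (0.79 log units; beyond the scatter) while chloro and ethynyl themselves stand level within the scatter. The position is therefore not indifferent to substitution, and the larger group with its added aromatic ring is tolerated less well than either earlier group. Nothing at hand accounts for the rise.

As far as these compounds go, whether the rise belongs to the amide link, the added ring or its chlorine remains open. A carboxylic acid, an amine or an unsubstituted phenylcarbamoyl at this place would help to separate these parts.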